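The compounds below may be only part of what the source reports. "The series", "measured", "known", "first", "only" and "open" are said of these compounds alone.

In a functional assay on A549 cells (Homo sapiens) for cytotoxicity, read by MTT assay, with a stated time of 48 h (a higher number here means a weaker inhibitor, a lower number a stronger inhibitor), compound 1 `C=C1C(=O)O[C@H]2CC3=C[C@H](C/C(C)=C/[C@@H](OC(=O)c4ccc(-c5ccccc5)cc4)[C@H]12)OC3=O` gives 4600 nM and compound 2 `C=C1C(=O)O[C@H]2CC3=C[C@H](C/C(C)=C/[C@@H](OC(=O)/C=C/c4ccccc4)[C@H]12)OC3=O` gives 4800 nM, two values within the usual scatter of each other. Compound 3 `C=C1C(=O)O[C@H]2CC3=C[C@H](C/C(C)=C/[C@@H](OC(=O)CCCCBr)[C@H]12)OC3=O` gives > 10000 nM, which is a limit of the assay and not a number. Compound 4 `C=C1C(=O)O[C@H]2CC3=C[C@H](C/C(C)=C/[C@@H](OC(=O)C(C)(C)CC)[C@H]12)OC3=O` has 1,1-dimethylpropyl in place of 4-bromobutyl on a carbonyl carbon. Within the data shown here, only one measured step bears on this change, an at least 2.0-fold higher number from compound 2 to compound 3 (0.31 log units; beyond the scatter), and it brought in a group with no ring. The new group in compound 4 also has no ring, so a similarly weak result is expected in this assay. The estimated step is an at least 1.1-fold lower number from compound 3 to compound 4 (0.04 log units; that floor lies within the scatter), expected to stay within the scatter or close to it. For compound 4 the estimated value is 9000 nM, with an expected range from 4000 nM to 20000 nM.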

Compound 4, half-maximal inhibitory concentration: 2200 nM
Compound 4: the middle estimate sits 4.1-fold (0.61 log units) above what was measured, outside the stated range (below it).
By their numbers in this assay, from the lowest: compound 4; then compounds 1 and 2 (each within the scatter of the next). At a limit, above all of these: compound 3.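

In this assay, a group with no ring on this carbonyl carbon does not have to give a weak result: 1,1-dimethylpropyl in place of 2-phenylethenyl gives a 2.2-fold lower number from compound 2 to compound 4 (0.34 log units; beyond the scatter). Two groups without a ring, each with 5 heavy atoms, can also differ clearly, with an at least 4.5-fold lower number from compound 3 to compound 4 (0.65 log units; beyond the scatter). The value of compound 3 is a limit and not a number: the limit of > 10000 nM in this assay, at which 1 of the 4 values shown sits.

The bromine and the branching change together here, so the compounds shown do not separate them. From the compounds shown here alone, a plain butyl group would separate them, and how a chain carrying an amine would behave remains open.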